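The source may hold more compounds than are shown below. What is called first, only, known or untested is meant among the compounds shown, and "the series" means these compounds.

Of the compounds shown here, two of a shared core have been measured in a functional assay on the whole organism (strain Wistar) for inhibition, with Rattus norvegicus as the target, read by paw edema, with stated times of 30 min and 60 min, at a dose of 50 mg/kg by the oral route; a lower number here means less inhibition, a higher number more inhibition at the dose given (going by the name of the read-out). Compound 1 `O=CN1N=C(c2ccc(Cl)cc2)CC1c1cn(-c2ccccc2)nc1-c1ccc(Cl)c(Cl)c1` gives 51.1% in this assay. Compound 2 `CC(=O)N1N=C(c2ccc(F)cc2)CC1c1cn(-c2ccccc2)nc1-c1ccc(Cl)c(Cl)c1` gives 59.5% in this assay, the higher of the two numbers, though the gap to compound 1 is within the scatter, so the two cannot be ranked against each other. Among the measured compounds shown here, compound 1 and compound 2 differ in two places at once, and no single step between them can be read off; their values simply stand side by side.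

Compound 3 `CC(=O)N1N=C(c2ccc(Cl)cc2)CC1c1cn(-c2ccccc2)nc1-c1ccc(Cl)c(Cl)c1` has not yet been measured. It differs from compound 2 in one place only: chloro in place of fluoro on an aromatic carbon. For the measured compounds named here, with no measured pair showing this change on its own, the only point of reference is that compound 1, which carries the chloro group at this position together with a different group elsewhere, shows 51.1%. He therefore expects the step of a number 4.5 percentage points lower from compound 2 to compound 3 (within the scatter) to stay within the scatter. His estimate for compound 3 in this assay is 55%, with a range from 40% to 70%.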

Compound 3, a percentage reported as inhibition, in the whole organism at one dose (the size of the read-out at that dose, not a potency): 57.3%
Compound 3: middle estimate off by 2.3 percentage points, on the low side; the measured number falls inside the stated range.
By their numbers in this assay, from the lowest: compounds 1, 3 and 2 (each within the scatter of the next).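

Among the compounds shown here, with compound 3, the change from 4-fluorophenyl to 4-chlorophenyl can be read on its own for the first time: in this assay, it amounts to a number 2.2 percentage points lower from compound 2 to compound 3 (within the scatter), so at this place, para to a large group, fluoro and chloro cannot be told apart at the dose given. Compound 3 also isolates a second change, methyl in place of hydrogen on a carbonyl carbon, which amounts to a number 6.2 percentage points higher from compound 1 to compound 3 (within the scatter) in this assay, so this change does not separate the two compounds either. No independent measurement bears on these two results.

The compounds shown leave open whether any change at either place can move the number in this assay beyond the scatter, since both single steps so far are small replacements of one group by another. A methoxy group or an amine in place of the chloro on the aromatic carbon, or a longer chain in place of the methyl on the carbonyl carbon, would test this, and a single oral dose cannot say how potency compares across the series.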